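Trimming a 4-Methoxybenzyl Arm Down to Methyl

A few compounds are considered here, and "the series" means these few. Any claim that something is new, unique, unknown or untested is made for them only; others in the source may bear on it.

Compound 1 `COc1ccc(Cn2c(=O)n(C3OC(CO)[C@@H](O)[C@H]3O)c3nc(N)nc(O)c32)cc1` is one of three related compounds measured in a functional assay with Mus musculus as the target; on this read-out lower numbers stand for an effect already at smaller amounts and higher numbers for an effect only at larger amounts of compound. In this assay compound 1 gives 2 uM, the lowest of the three numbers. Compound 2 `C=CCn1c(=O)n([C@H]2CO[C@@H](CO)C2)c2nc(N)nc(O)c21` gives 272 uM, and compound 3 `CCCn1c(=O)n(C2C=CC(CO)O2)c2nc(N)nc(O)c21` gives 52 uM; both stand beyond the usual scatter from compound 1, yet each differs from compound 1 in more than one place, so neither pair isolates a single change and only the two values themselves can be set side by side.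

Compound 4 `Cn1c(=O)n(C2OC(CO)[C@@H](O)[C@H]2O)c2nc(N)nc(O)c21` keeps the remainder of compound 1 and differs from it in one place: hydrogen in place of 4-methoxyphenyl on a saturated chain carbon bound to an aromatic nitrogen. The same difference, cut one bond further out, reads 4-methoxybenzyl to methyl. Going by the values given here, no pair of measured compounds shows this change on its own. Compounds 2 and 3 also lack the 4-methoxyphenyl group and give larger numbers. Among the compounds with values here, they differ from compound 1 in other places too, and no measured pair separates that group from the other changes. A rise in the number is expected for compound 4, with the step of a 10-fold higher number from compound 1 to compound 4 (1.00 log units; beyond the scatter) estimated to exceed the scatter. Compound 4 is expected to give about 20 uM in this assay, within a range of 3 uM to 150 uM.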

Compound 4, concentration for half-maximal effect: 120 uM
The estimate for compound 4 lay 6.0-fold (0.78 log units) below the measured number; low and high end bracket the measured number.
By their numbers in this assay, from the lowest: compound 1; then compound 3; then compound 4; then compound 2.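

Replacing the 4-methoxyphenyl group with hydrogen, on a saturated chain carbon bound to an aromatic nitrogen, gives in this assay a 60-fold higher number from compound 1 to compound 4 (1.78 log units; beyond the scatter), a large step well beyond the usual scatter. The earlier compounds shown here could not show this, as each differed from compound 1 in more than one place, whereas here the rest of the molecule stays the same and the step belongs to this one change. On this core, then, the read-out depends strongly on whether this place carries 4-methoxybenzyl or methyl, but the data shown offer no measured reason for the rise.

Going by these compounds, with only these two groups compared at this place, it remains open whether the effect needs the whole 4-methoxybenzyl group or only part of it, which a plain benzyl group, lacking the methoxy, or a butyl chain, lacking the ring, could help separate. It is also unknown whether the same change would produce a step of similar size on a different core, such as that of compound 2 or compound 3.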